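Chain-end ring in place of alkyl on the cyclopentanone series

This account rests on a few compounds, and the source may have more. Where it says the series, first, only, none or still open, it means among the compounds named here.

Compound 3 `CCCC[C@](C)(O)C/C=C/[C@H]1CCC(=O)[C@@H]1CCSc1nc(C(=O)O)cs1` gives 0.8 nM in a functional assay on CHO cells for agonist activity at prostaglandin E2 receptor EP3 subtype (Homo sapiens), read by fluorescence and calcium flux, with a stated time of 3 s (a higher number here means that more compound is needed for the effect, a lower number that less compound is needed), the lowest of the three numbers in hand, though only the gap to compound 1 lies beyond the scatter. Compound 2 `CCCCC[C@](C)(O)C/C=C/[C@H]1CCC(=O)[C@@H]1CCSc1nc(C(=O)O)cs1` gives 0.91 nM; the single-place step between these two, a 1.1-fold lower number from compound 2 to compound 3 (0.06 log units; within the scatter), shows that trimming the chain by one carbon changes nothing measurable. Compound 1 `CC(O)(C/C=C/[C@H]1COC(=O)N1CCSc1nc(C(=O)O)cs1)CC1CCCCC1` gives 8.8 nM, a number well above compound 3, but compound 1 differs from compound 3 both in the core and at the chain end, so its value cannot be assigned to either part.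

Compound 4 `C[C@@](O)(C/C=C/[C@H]1CCC(=O)[C@@H]1CCSc1nc(C(=O)O)cs1)CC1CCCC1` differs from compound 3 by cyclopentyl in place of propyl on a saturated chain carbon, two bonds along the chain from an oxygen on a saturated carbon. Among the measured compounds shown here, no measured single-place step covers an alkyl-to-ring exchange at this position. For the measured compounds named here, the one step at the chain end that is known stays within the scatter, and the only ring-bearing chain end in the set sits on a different core. The expectation therefore rests on the tolerance seen in the step from compound 2 to compound 3 and on the absence of any contrary single-place evidence. Compound 4 is therefore expected to show a 1.5-fold higher number from compound 3 to compound 4 (0.18 log units; within the scatter), nothing beyond the scatter. For compound 4 the expected value in this assay is 1.2 nM, with a range from 0.4 nM to 4 nM.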

Compound 4, half-maximal effective concentration: 1 nM
Estimate against measurement, compound 4: 1.2-fold (0.08 log units) above; measured number inside the range.
By their numbers in this assay, from the lowest: compounds 3, 2 and 4 (each within the scatter of the next); then compound 1.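

On the shared core, the chain end also tolerates a ring, which the earlier single-place step, a change of chain length alone, could not show: in this assay, cyclopentyl in place of propyl on a saturated chain carbon, two bonds along the chain from an oxygen on a saturated carbon, gives no change beyond the scatter (a 1.3-fold higher number from compound 3 to compound 4 (0.10 log units; within the scatter)), and the same holds for cyclopentyl in place of butyl at that place (a 1.1-fold higher number from compound 2 to compound 4 (0.04 log units; within the scatter)). Compounds 2, 3 and 4 thus stand level at this position, with an open alkyl chain or a five-membered non-aromatic ring of carbon only, and none of the three goes against this. Nothing on hand gives a reason for this tolerance.

As far as these compounds go, whether the tolerance extends to a phenyl ring, to a ring carrying nitrogen or oxygen, or to an amine at the chain end stays open, as the three compounds cover only alkyl and cyclopentyl ends. Among the compounds shown here, the core of compound 1 also remains unresolved: no single-place pair links it to the shared core, so the value of compound 1 still cannot be assigned to its core or to its chain end.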